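The compounds below may be only part of what the source reports. "The series", "measured", "known", "first", "only" and "open" are said of these compounds alone.

In a functional assay on HL-60 cells (Homo sapiens) for inhibition, read by MTT assay, with a stated time of 72 h (on this read-out lower numbers stand for stronger inhibition and higher numbers for weaker inhibition), compound 1 (`Cc1ccc(C)c(N2CCN(C(=O)c3oc(C)nc3-c3ccc(F)cc3)CC2)c1`) gives 358 nM while compound 2 (`Cc1ccc(C)c(N2CCN(C(=O)c3oc(C)nc3-c3cccc(Cl)c3)CC2)c1`) gives 345 nM and compound 3 (`Cc1ccc(C)c(N2CCN(C(=O)c3oc(C)nc3-c3ccccc3F)CC2)c1`) gives 319 nM and these three values sit within the usual scatter of each other, so compound 1 stands level with both. Compound 4 (`COc1cc(OC)cc(N2CCN(C(=O)c3oc(C)nc3-c3ccc(F)cc3)CC2)c1`) keeps the core of compound 1 but carries 3,5-dimethoxyphenyl in place of 2,5-dimethylphenyl on an amine nitrogen in a ring. The measured steps are a 1.0-fold lower number from compound 1 to compound 2 (0.02 log units; within the scatter) and a 1.1-fold lower number from compound 1 to compound 3 (0.05 log units; within the scatter) and a 1.1-fold lower number from compound 2 to compound 3 (0.03 log units; within the scatter) and all sit within the scatter, yet each swaps a phenyl group at another place, so none tests this change. With no measured guide to direction, the estimated step is a 1.1-fold lower number from compound 1 to compound 4 (0.04 log units; within the scatter) and no shift beyond the scatter is expected, though the uncertainty is wide. For compound 4 the estimated value is 330 nM with an expected range from 100 nM to 1100 nM across repeat measurements.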

Compound 4, half-maximal inhibitory concentration: 38.5 nM
Beside the measured number, compound 4's estimate is 8.6-fold (0.93 log units) above it, outside the stated range (below it).
By their numbers in this assay, from the lowest: compound 4; then compounds 3, 2 and 1 (each within the scatter of the next).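

Changing the group on the ring nitrogen from 2,5-dimethylphenyl to 3,5-dimethoxyphenyl in this assay gives a 9.3-fold lower number from compound 1 to compound 4 (0.97 log units; beyond the scatter) and so moves the number beyond the scatter. The earlier swaps on the other phenyl group did not do this, so among these compounds the ring nitrogen's group is the place where a change has shown up. No available evidence accounts for the shift.

This swap alters both the kind of group and the pattern of substitution, and the compounds shown do not separate the two. On these data alone, whether 3,5-dimethylphenyl or a phenyl ring with hydroxyl groups would behave alike also stays open.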